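This account rests on a few compounds, and the source may have more. Where it says the series, first, only, none or still open, it means among the compounds named here.

In a functional assay on HOS-TE85 cells (Homo sapiens) for inhibition, read by CCK-8 assay, with a stated time of 72 h (a lower number here means a stronger inhibitor, a higher number a weaker inhibitor), compound 2 `COc1ccccc1N1C(=O)CSC1c1cccc(C(=O)NCCCCc2ccc(Cl)cc2)c1` gives 78.6 nM, the lower of the two actual numbers, while compound 1 `COc1ccc(C)cc1N1C(=O)CSC1c1cccc(C(=O)NCCCCc2ccccc2)c1` gives 300 nM. Compound 3 `CC(C)(C)c1conc1N1C(=O)CSC1c1cccc(C(=O)NCCCCc2ccccc2)c1` reads > 1000 nM, which is a limit and not a number. Compound 4 `COc1ccccc1N1C(=O)CSC1c1cccc(C(=O)NCCCCN2C(=O)C=CC2=O)c1` differs from compound 2 by a group of 7 heavy atoms (4 carbon, 1 nitrogen, 2 oxygen; one five-membered non-aromatic ring with 1 hetero atom) in place of a group of 7 heavy atoms (6 carbon, 1 chlorine; one six-membered aromatic ring of carbon only), on a saturated chain carbon, four bonds along the chain from an amide-type nitrogen. Going by the values given here, the only measured step, an at least 3.3-fold higher number from compound 1 to compound 3 (0.52 log units; beyond the scatter), changes the group on an amide-type nitrogen in a ring, not this group, so it bears on the change only indirectly and no measured step sizes it. A modest move toward a higher number is nevertheless expected, with wide uncertainty. The estimated change is a 3.2-fold higher number from compound 2 to compound 4 (0.50 log units; beyond the scatter) in this assay. Compound 4 is expected at 250 nM, within an estimated range of 40 nM to 1500 nM.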

Compound 4, half-maximal inhibitory concentration: > 1000 nM
Compound 4 gave a limit, no number (the forecaster's own chance of this, stated with the estimate: 20%); middle value at least 4.0-fold (0.60 log units) from the limit.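

In this assay, putting the five-membered non-aromatic ring group in place of 4-chlorophenyl, on a saturated chain carbon, four bonds along the chain from an amide-type nitrogen, gives an at least 12-fold higher number from compound 2 to compound 4 (1.10 log units; beyond the scatter). This shows that the group at this place can matter as much as the group changed in the earlier step. Compound 4 reads a limit, so the true size of the step stays open because the value lies at the end of the measured range: the limit of > 1000 nM in this assay, at which 2 of the 4 values shown sit.

The compounds shown do not tell whether any group here other than 4-chlorophenyl keeps the lower number. Going by these compounds, how an amine, a carboxylic acid or a longer chain would read at this place remains unknown.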